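Shifting the aryl substituent on the shared core

The source may report more compounds than this note shows. Statements on the series, on what has been measured and on what is new or still open speak of the compounds shown alone.

Compound 3 `CC(C)OC(=O)N1CCC(Oc2ncnc3c2CCN3c2ccc(S(C)(=O)=O)c(F)c2)CC1` is the strongest responder of the three measured compounds: in a functional assay on CHO-K1 cells with Glucose-dependent insulinotropic receptor (Homo sapiens) as the target, read by a luciferase reporter, with a stated time of 5 h (on this read-out higher numbers stand for larger maximal responses and lower numbers for smaller maximal responses), compound 3 reaches 109%, while compound 2 `CC(C)OC(=O)N1CCC(Oc2ncnc3c2CCN3c2ccc(S(C)(=O)=O)nc2)CC1` gives 97% and compound 1 `CC(C)OC(=O)N1CCC(Oc2ncnc3c2CCN3c2ccc(S(C)(=O)=O)cc2F)CC1` gives 91%. The step from compound 1 to compound 3 was a number 18 percentage points higher from compound 1 to compound 3 (beyond the scatter), and the step from compound 2 to compound 3 was a number 12 percentage points higher from compound 2 to compound 3 (beyond the scatter); the step from compound 1 to compound 2 was a number 6 percentage points higher from compound 1 to compound 2 (within the scatter).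

Compound 4 `Cc1cc(S(C)(=O)=O)ccc1N1CCc2c(OC3CCN(C(=O)OC(C)C)CC3)ncnc21` differs from compound 3 in one place: 2-methyl-4-(methylsulfonyl)phenyl in place of 3-fluoro-4-(methylsulfonyl)phenyl on a nitrogen on an aromatic ring in a ring. Among the measured compounds shown here, two measured steps bear on this. The step from compound 1 to compound 3 shows that moving a single substituent on that aryl group from the 2-fluoro to the 3-fluoro arrangement raised the maximal response by a modest amount, while the step from compound 1 to compound 2 shows that swapping the aryl group itself changed little. Compound 4 carries its extra group, now a methyl, in the 2-position arrangement of compound 1 rather than the 3-position arrangement of compound 3, so a modest fall is expected, roughly back toward the value of compound 1, though no methyl-bearing aryl group has been measured here. The estimated step is a number 14 percentage points lower from compound 3 to compound 4 (beyond the scatter). Compound 4 is therefore expected to reach about 95%, in a range from 80% to 110%.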

Compound 4, largest response reached (reported as percent of maximum), in percent of the reference or control that the assay uses: 80%
For compound 4 the middle estimate is 15 percentage points above the measured one; low and high end bracket the measured number.
By their numbers in this assay, from the lowest: compound 4; then compounds 1 and 2 (each within the scatter of the next); then compound 3.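

Among the compounds shown here, compound 4 gives the smallest maximal response of the four in this assay, and replacing the 3-fluoro-4-(methylsulfonyl)phenyl group results in a number 29 percentage points lower from compound 3 to compound 4 (beyond the scatter), a larger step than any seen among the earlier compounds, while the comparison with the 6-(methylsulfonyl)pyridin-3-yl group gives a number 17 percentage points lower from compound 2 to compound 4 (beyond the scatter). The earlier compounds shown here showed that the response on this nitrogen shifted with the place of the fluoro group, but the change of methyl in place of fluoro on an aromatic carbon, with the rest of the aryl group kept, now gives a number 11 percentage points lower from compound 1 to compound 4 (beyond the scatter), so the identity of the group matters as well as its place. Nothing available here explains why the methyl group lowers the maximal response in this way.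

The compounds shown leave open whether 3-methyl-4-(methylsulfonyl)phenyl would recover the response of the 3-fluoro-4-(methylsulfonyl)phenyl group or stay as low as the 2-methyl-4-(methylsulfonyl)phenyl group. They also leave open how a chloro or methoxy group would compare with methyl and fluoro on this aryl group.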